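The compounds below may be only part of what the source reports. "The series", "measured", "known", "first", "only" and "open" are said of these compounds alone.

In a functional assay on HepG2 cells (Homo sapiens), read by MTT assay, with a stated time of 48 h (on this read-out higher numbers stand for weaker inhibition and lower numbers for stronger inhibition), compound 3 `CCN(CC)CCCNC(=O)c1ccc(C(CC)(CC)c2ccc(OCC(=O)C(C)(C)C)c(C)c2)n1CC` gives 180 nM, the lowest of three numbers, against compound 1 `CCN(CC)CCNC(=O)c1ccc(C(CC)(CC)c2ccc(OCC(=O)C(C)(C)C)c(C)c2)n1CC` at 620 nM and compound 2 `CCn1c(C(=O)NCCCN(C)C)ccc1C(CC)(CC)c1ccc(OCC(=O)C(C)(C)C)c(C)c1` at 960 nM. Compound 4 `CC[C@@H](C)[C@H](NC(=O)c1ccc(C(CC)(CC)c2ccc(OCC(=O)C(C)(C)C)c(C)c2)n1CC)C(=O)O` differs from compound 3 as follows: 1-carboxy-2-methylbutyl in place of 3-(diethylamino)propyl on an amide-type nitrogen. In words, this puts 1-carboxy-2-methylbutyl in place of 3-(diethylamino)propyl on an amide-type nitrogen. The closest evidence is modest: a 3.4-fold lower number from compound 1 to compound 3 (0.54 log units; beyond the scatter) and a 5.3-fold lower number from compound 2 to compound 3 (0.73 log units; beyond the scatter), while a 1.5-fold higher number from compound 1 to compound 2 (0.19 log units; within the scatter) stays within the scatter. All three compounds keep an amino-ended chain, so none of these steps covers its removal, and the estimate is loose. The expected step is a rise larger than those, a 14-fold higher number from compound 3 to compound 4 (1.14 log units; beyond the scatter). For compound 4 the estimated value is 2500 nM, with an expected range of 600 nM to 10000 nM.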

Compound 4, half-maximal inhibitory concentration: 247 nM
The estimate for compound 4 lay 10-fold (1.01 log units) above the measured number; measured number below the stated range.
By their numbers in this assay, from the lowest: compounds 3 and 4 (each within the scatter of the next); then compounds 1 and 2 (each within the scatter of the next).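

In this assay, the chain on the amide-type nitrogen need not end in an amine: 1-carboxy-2-methylbutyl in place of 3-(diethylamino)propyl gives a 1.4-fold higher number from compound 3 to compound 4 (0.14 log units; within the scatter). Against the other two amino-ended chains, the same group gives a 3.9-fold lower number from compound 2 to compound 4 (0.59 log units; beyond the scatter) and a 2.5-fold lower number from compound 1 to compound 4 (0.40 log units; beyond the scatter). No measurement available here explains this tolerance.

Still open, from the compounds shown here alone, is whether the carboxylic acid or the branched hydrocarbon part of 1-carboxy-2-methylbutyl carries this result. A methyl ester, an unbranched carboxylic acid chain or the other stereoisomers would separate these possibilities.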